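Replacing Chloro with a Second Amide Chain

The source may hold more compounds than are shown below. What is called first, only, known or untested is meant among the compounds shown, and "the series" means these compounds.

In a functional assay on the whole organism (strain Sprague-Dawley CD) for inhibition, with Rattus norvegicus as the target, read by paw edema, at a dose of 100 mg/kg by the oral route (on this read-out lower numbers stand for a weaker effect and higher numbers for a stronger effect at the one dose given), compound 1 `CCOC(=O)C(=O)Nc1cccccc1=O` gives 91%, compound 2 `CCOC(=O)C(=O)Nc1ccc(OC)ccc1=O` gives 53%, and compound 3 `CCOC(=O)C(=O)Nc1ccc(Cl)ccc1=O` gives 25%. Compound 3 thus stands lowest of the three, with a number 66 percentage points lower from compound 1 to compound 3 (beyond the scatter) and a number 28 percentage points lower from compound 2 to compound 3 (beyond the scatter), both beyond the scatter. The unmeasured compound 4 `CCOC(=O)C(=O)Nc1ccc(NC(=O)C(=O)OCC)c(=O)cc1` differs from compound 3 in one place: ((ethoxycarbonyl)carbonyl)amino in place of chloro on an aromatic carbon. Among the measured compounds shown here, no measured step exchanges this particular group, so the bearing steps are indirect: each group placed on the seven-membered aromatic ring lowered the number, as a number 38 percentage points lower from compound 1 to compound 2 (beyond the scatter) and a number 66 percentage points lower from compound 1 to compound 3 (beyond the scatter) show, while the exchange of one such group for another, a number 28 percentage points lower from compound 2 to compound 3 (beyond the scatter), was modest. Because a number 28 percentage points lower from compound 2 to compound 3 (beyond the scatter) shows that swapping one group on this ring for another moves the number by a modest amount, a step of similar or somewhat larger size, most likely upward from the lowest value, is expected for compound 4, namely a number 15 percentage points higher from compound 3 to compound 4 (beyond the scatter). Compound 4 is therefore estimated at 40%, within a range from 10% to 75%.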

Compound 4, a percentage reported as inhibition, in the whole organism at one dose (the size of the read-out at that dose, not a potency): 76%
Compound 4: the middle estimate sits 36 percentage points below what was measured; measured number outside the range, above it.
By their numbers in this assay, from the lowest: compound 3; then compound 2; then compound 4; then compound 1.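

In this assay, a group on this ring carbon need not cost most of the effect: ((ethoxycarbonyl)carbonyl)amino in place of chloro gives a number 51 percentage points higher from compound 3 to compound 4 (beyond the scatter), and in place of methoxy it gives a number 23 percentage points higher from compound 2 to compound 4 (beyond the scatter). The same group in place of hydrogen still gives a number 15 percentage points lower from compound 1 to compound 4 (beyond the scatter), so all three groups fall short of hydrogen here, but this one by only a modest step. Among these three groups, the one with the most heavy atoms does not give the lowest number, so size alone does not set their order. Nothing available explains why the groups differ. Going by these compounds, it remains open which part of the chain matters: a simple amine, or a carboxylic acid in place of the ethyl ester, would help separate the contributions of its parts.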